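Cyclobutyl for ethyl on a second core

A few compounds are considered here, and "the series" means these few. Any claim that something is new, unique, unknown or untested is made for them only; others in the source may bear on it.

Compound 1 `CCNc1n[n+]([O-])c2cc(Br)ccc2[n+]1[O-]` and compound 2 `[O-][n+]1nc(NC2CCC2)[n+]([O-])c2ccc(Br)cc21` share one core and differ only at the amino group. In an ADME assay on Vero cells (Chlorocebus sabaeus) for cytotoxicity, read by CellTiter-Glo, with a stated time of 72 h (a lower number here means that less compound is tolerated, a higher number that more compound is tolerated), compound 1 gives 4.2 ug/mL, and compound 2 gives 3.8 ug/mL. The change from compound 1 to compound 2 is cyclobutyl in place of ethyl on a nitrogen on an aromatic ring, and the step it made was a 1.1-fold lower number from compound 1 to compound 2 (0.04 log units; within the scatter), so the two numbers are not distinguished here.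

Compound 3 `CCNc1n[n+]([O-])c2cccc(C)c2[n+]1[O-]` sits on a different core; the difference between the two cores is not broken down here. In this assay compound 3 gives 22 ug/mL, the highest of the three numbers and beyond the scatter from both compound 1 and compound 2.

Compound 4 `Cc1cccc2c1[n+]([O-])c(NC1CCC1)n[n+]2[O-]` has not yet been measured. It differs from compound 3 by cyclobutyl in place of ethyl on a nitrogen on an aromatic ring, the same change as from compound 1 to compound 2, at the same kind of place. Because a 1.1-fold lower number from compound 1 to compound 2 (0.04 log units; within the scatter) lay within the scatter, the step from compound 3 to compound 4 is expected to be a 1.1-fold lower number from compound 3 to compound 4 (0.04 log units; within the scatter), though it rests on a single pair on another core. Compound 4 is therefore estimated to give 20 ug/mL in this assay, between 8 ug/mL and 45 ug/mL.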

Compound 4, half-maximal cytotoxic concentration: 22 ug/mL
Beside the measured number, compound 4's estimate is 1.1-fold (0.04 log units) below it; measured number inside the range.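

In this assay, cyclobutyl in place of ethyl on a nitrogen on an aromatic ring gave no change at the digits printed from compound 3 to compound 4 (within the scatter). Set beside the earlier step, the same change gave the same result on both cores, with nothing to tell the two steps apart: the same change on two cores in this assay, a 1.1-fold lower number (0.04 log units; within the scatter) from compound 1 to compound 2 and no change at the digits printed (within the scatter) from compound 3 to compound 4, 1.1-fold (0.04 log units) apart, within the scatter of two such steps. This shows that, for these two pairs and in this one assay, ethylamino to cyclobutylamino leaves the number in place on either core, but two pairs cannot show that it would do so on a further core, and they say nothing about what separates the two cores themselves.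

The compounds shown leave open whether a different group at the same nitrogen, such as cyclopropyl, cyclohexyl, a longer chain or a chain ending in a hydroxyl group, would also leave the number in place. They also leave open whether the agreement between the two steps would hold on a core carrying chloro or methoxy on the ring.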